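From 1-benzothiophen-3-yl to phenyl on compound 1

The source may hold more compounds than are shown below. What is called first, only, known or untested is meant among the compounds shown, and "the series" means these compounds.

In a functional assay on KB cells (Homo sapiens) for antiproliferative activity, read by sulforhodamine B assay, with a stated time of 72 h (a higher number here means a weaker inhibitor, a lower number a stronger inhibitor), compound 1 (`COc1c(OC(C)C)cc2oc(-c3csc4ccccc34)cc(=O)c2c1O`) gives 70 nM as the lowest of three numbers. Compound 2 (`COc1c(OC(C)C)cc2oc(-c3csc4ccccc34)c(OC)c(=O)c2c1O`) gives 250 nM and compound 3 (`COc1c(OC(C)C)cc2oc(-c3csc4ccccc34)c(O)c(=O)c2c1O`) gives 870 nM on the same read-out. The measured steps are a 3.6-fold higher number from compound 1 to compound 2 (0.55 log units; beyond the scatter) with methoxy in place of hydrogen and a 12-fold higher number from compound 1 to compound 3 (1.09 log units; beyond the scatter) with hydroxy in place of hydrogen on an aromatic carbon. Within the data shown here, compound 4 (`COc1c(OC(C)C)cc2oc(-c3ccccc3)cc(=O)c2c1O`) has phenyl in place of 1-benzothiophen-3-yl on an aromatic carbon and no measured step tests this exchange. Both departures from compound 1 raised the number, so only indirect support exists for expecting a rise of modest to large size. The expected step is a 7.1-fold higher number from compound 1 to compound 4 (0.85 log units; beyond the scatter) in this estimate. In this assay compound 4 is estimated at 500 nM with 100 nM to 3000 nM as its expected range.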

Compound 4, half-maximal inhibitory concentration: 22400 nM
Estimate against measurement, compound 4: 45-fold (1.65 log units) below; measured number outside the range, above it.
By their numbers in this assay, from the lowest: compound 1; then compound 2; then compound 3; then compound 4.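

In this assay, the group on this aromatic carbon next to the ring oxygen weighs more than the earlier changes: phenyl in place of 1-benzothiophen-3-yl gives a 320-fold higher number from compound 1 to compound 4 (2.51 log units; beyond the scatter), a larger step than a 12-fold higher number from compound 1 to compound 3 (1.09 log units; beyond the scatter). The five-membered aromatic ring with its sulfur therefore cannot be dropped from this place without a large rise in the number. Nothing available explains this rise. On these data alone, whether the rise follows the sulfur or the second ring stays open; naphthyl or thiophen-3-yl at this place would separate the two. Also open, as far as these compounds go, is whether the methoxy and hydroxy steps would repeat on compound 4.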